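A piperazine in place of methylamino on a shared core

The source may hold more compounds than are shown below. What is called first, only, known or untested is meant among the compounds shown, and "the series" means these compounds.

Of the compounds shown here, two sharing one core have been measured in a functional assay on K562 cells (Homo sapiens) for cytotoxicity, read by MTT assay, with a stated time of 3 days; on this read-out lower numbers stand for stronger inhibition and higher numbers for weaker inhibition. Compound 1 `N#Cc1c(NN)nc(SCc2nc3ccccc3[nH]2)nc1-c1ccccc1` gives 14.7 nM in this assay. Going by the values given here, compound 2 `CNc1nc(SCc2nc3ccccc3[nH]2)nc(-c2ccccc2)c1C#N` gives 13.2 nM in this assay, and the single step between them, a 1.1-fold lower number from compound 1 to compound 2 (0.05 log units; within the scatter), arises from methyl in place of amino on a nitrogen on an aromatic ring. On the numbers shown, compound 2 therefore stands beside compound 1, with nothing to separate the two beyond the scatter.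

Compound 3 `N#Cc1c(-c2ccccc2)nc(SCc2nc3ccccc3[nH]2)nc1N1CCNCC1` is not yet measured in this assay. It differs from compound 2 by piperazin-1-yl in place of methylamino on an aromatic carbon. Among the compounds with values here, no measured step touches this position with a change of ring for chain; the only step available, from compound 1 to compound 2, altered a group on a nitrogen and stayed within the scatter, so it offers little guidance on the size of the present change. The step of a 1.5-fold higher number from compound 2 to compound 3 (0.18 log units; within the scatter) is what the writer expects, with wide uncertainty. The estimate for compound 3 in this assay is 20 nM, expected to lie between 5 nM and 80 nM.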

Compound 3, half-maximal inhibitory concentration: 4.38 nM
Estimate against measurement, compound 3: 4.6-fold (0.66 log units) above, and the stated range ends above it.
By their numbers in this assay, from the lowest: compound 3; then compounds 2 and 1 (each within the scatter of the next).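

Until this result, the two groups seen on the aromatic carbon ortho to a cyano group, aminoamino in compound 1 and methylamino in compound 2, had given numbers within the scatter of each other in this assay, so the position had shown no response. Piperazin-1-yl is the first group there to move the number beyond the scatter, and it moves it downward against both open-chain groups, modestly in each case (a 3.0-fold lower number from compound 2 to compound 3 (0.48 log units; beyond the scatter); a 3.4-fold lower number from compound 1 to compound 3 (0.53 log units; beyond the scatter)). The step shows that this place accepts a six-membered non-aromatic ring with 2 hetero atoms in place of a short chain without loss in this read-out, though nothing at hand accounts for the gain.

The entering group brings the ring and its second nitrogen together, so the three compounds leave open which of the two goes with the lower number; a piperidine or a morpholine at this place would separate them, and a methyl on the free piperazine nitrogen would show whether that hydrogen matters. From the compounds shown here alone, whether the same step holds on cells other than K562 also stays open.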